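The compounds below may be only part of what the source reports. "The series", "measured", "known", "first", "only" and "open" are said of these compounds alone.

Of the compounds shown here, two have been measured in a functional assay on PC-3 cells (Homo sapiens) for cytotoxicity, read by MTT assay, with a stated time of 48 h; on this read-out lower numbers stand for stronger inhibition and higher numbers for weaker inhibition. Compound 2 `CCCNCC(=O)N1N=C(c2cc3ccccc3oc2=O)CC1c1ccccc1` gives 7270 nM in this assay. Compound 1 `CC1=NN(C(=O)CN2CCN(C)CC2)C(c2ccccc2O)C1`, built on a different core, gives 11800 nM; the gap between these two numbers lies within the usual scatter, so they count as alike. Compound 3 `CN1CCN(CC(=O)N2N=C(c3cc4ccccc4oc3=O)CC2c2ccccc2)CC1` is compound 2 with one change: 4-methylpiperazin-1-yl in place of propylamino on a saturated chain carbon bound to a carbonyl carbon. Going by the values given here, no measured pair shows the effect of this swap, so the step from compound 2 to compound 3 is expected to stay within the scatter, a 1.2-fold higher number from compound 2 to compound 3 (0.09 log units; within the scatter). Compound 3 is therefore estimated at 9000 nM, with a range from 4000 nM to 20000 nM.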

Compound 3, half-maximal inhibitory concentration: 25800 nM
For compound 3 the middle estimate is 2.9-fold (0.46 log units) below the measured one; measured number above the stated range.
By their numbers in this assay, from the lowest: compounds 2 and 1 (each within the scatter of the next); then compound 3.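

With a 3.5-fold higher number from compound 2 to compound 3 (0.55 log units; beyond the scatter) in this assay the saturated chain carbon bound to a carbonyl carbon proves sensitive to which amine it carries. Replacing propylamino with 4-methylpiperazin-1-yl adds a six-membered ring and removes the hydrogen-bond donor, and this combined change weakens inhibition here. No measurement available explains the step.

On these data alone, whether the ring, the lost donor or the larger size matters remains open. Piperidin-1-yl or butylamino at this position could help separate these differences.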